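The source may report more compounds than this note shows. Statements on the series, on what has been measured and on what is new or still open speak of the compounds shown alone.

In an ADME assay on cells (Hepatocyte, Homo sapiens) for metabolic stability, read by LC-MS, with a stated time of 10 min, tested at 1 uM (a higher number here means faster removal of the compound, a lower number slower removal), compound 2 `O=C(NCc1ccc(S(=O)(=O)c2cc(F)cc(F)c2)cc1)c1cc2cnccc2[nH]1` gives 7 mL/min/kg and compound 1 `O=C(NCc1ccc(S(=O)(=O)c2cccc(C(F)(F)F)c2)cc1)c1cc2cnccc2[nH]1` gives 10 mL/min/kg, which places the two level within the scatter. Going by the values given here, the only measured step, a 1.4-fold lower number from compound 1 to compound 2 (0.15 log units; within the scatter), puts 3,5-difluorophenyl in place of 3-(trifluoromethyl)phenyl on a sulfonyl sulfur, and it stays within the scatter. Compound 3 `O=C(NCc1ccc(S(=O)(=O)c2cc(F)cc(F)c2)cc1)c1cnc2nccn2c1` keeps the 3,5-difluorophenyl of compound 2 and differs on the carbonyl carbon: a group of 9 heavy atoms (6 carbon, 3 nitrogen; one five-membered aromatic ring with 2 hetero atoms, one six-membered aromatic ring with 2 hetero atoms) in place of a group of 9 heavy atoms (7 carbon, 2 nitrogen; one five-membered aromatic ring with 1 hetero atom, one six-membered aromatic ring with 1 hetero atom), on a carbonyl carbon. Among the compounds with values here, no measured step touches that group, so a 1.4-fold lower number from compound 1 to compound 2 (0.15 log units; within the scatter) bears on this change only weakly and gives no direction for it. The series therefore offers no basis for expecting a real shift in this assay, although the uncertainty is wide. The estimated step is a 1.3-fold higher number from compound 2 to compound 3 (0.11 log units; within the scatter), which is expected to remain within the scatter. Compound 3 is expected at 9 mL/min/kg, with an estimated range of 4 mL/min/kg to 20 mL/min/kg.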

Compound 3, clearance: 6 mL/min/kg
Compound 3: the middle estimate sits 1.5-fold (0.18 log units) above what was measured, and the stated range covers the measured number.
By their numbers in this assay, from the lowest: compounds 3, 2 and 1 (each within the scatter of the next).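

In this assay, the carbonyl carbon now has a measured step of its own: a 1.2-fold lower number from compound 2 to compound 3 (0.07 log units; within the scatter). The entering group has 0 hydrogen-bond donors and 3 hydrogen-bond acceptors, against 1 hydrogen-bond donor and 1 hydrogen-bond acceptor in the group it replaces, so with the 3,5-difluorophenyl held fixed, this exchange of two groups of 9 heavy atoms leaves the reading level within the scatter. No supporting measurement is available to explain this result.

Going by these compounds, it remains open whether the same exchange would also stay level with 3-(trifluoromethyl)phenyl on the sulfonyl sulfur. The compounds shown also leave open how the reading responds on the carbonyl carbon to a different kind of group, such as an open-chain amine or a single phenyl ring.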